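From 3-ethylphenyl to 2,3-dimethylphenyl on a sulfonamide nitrogen

This account rests on a few compounds, and the source may have more. Where it says the series, first, only, none or still open, it means among the compounds named here.

In a functional assay on MCF7 cells (Homo sapiens) for antiproliferative activity, read by sulforhodamine B assay, with a stated time of 48 h (on this read-out higher numbers stand for weaker inhibition and lower numbers for stronger inhibition), compound 1 `Cc1ccc(NS(=O)(=O)c2ccc(N3CCNC3=O)cc2)cc1` gives 610 nM, compound 2 `CCc1ccc(NS(=O)(=O)c2ccc(N3CCNC3=O)cc2)cc1` gives 810 nM, and compound 3 `CCc1cccc(NS(=O)(=O)c2ccc(N3CCNC3=O)cc2)c1` gives 130 nM, the lowest of the three. Compound 4 `Cc1cccc(NS(=O)(=O)c2ccc(N3CCNC3=O)cc2)c1C` has the same atoms as compound 3, joined differently: 2,3-dimethylphenyl takes the place of 3-ethylphenyl on a sulfonamide nitrogen (2,3-dimethylphenyl in place of 3-ethylphenyl on a sulfonamide nitrogen).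

Among the compounds with values here, three measured steps bear on this change. Adding a methyl in place of hydrogen on the chain carbon gives a 1.3-fold higher number from compound 1 to compound 2 (0.12 log units; within the scatter). Moving to 3-ethylphenyl gives a 4.7-fold lower number from compound 1 to compound 3 (0.67 log units; beyond the scatter) and a 6.2-fold lower number from compound 2 to compound 3 (0.79 log units; beyond the scatter). As its name shows, the incoming group also carries a substituent at position 3, so most of that advantage is expected to remain. Within the data shown here, no measured compound has a substituent at position 2, which leaves that part of the change untested and argues for a wide range.

The expected change is small, leaning towards a higher number: a 1.7-fold higher number from compound 3 to compound 4 (0.23 log units; within the scatter). For compound 4 the estimated value is 220 nM, with an expected range of 70 nM to 650 nM.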

Compound 4, half-maximal inhibitory concentration: 230 nM
Estimate against measurement, compound 4: 1.0-fold (0.02 log units) below; the range from low to high includes it.
By their numbers in this assay, from the lowest: compounds 3 and 4 (each within the scatter of the next); then compounds 1 and 2 (each within the scatter of the next).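

In this assay, 2,3-dimethylphenyl in place of 3-ethylphenyl on a sulfonamide nitrogen gives a 1.8-fold higher number from compound 3 to compound 4 (0.25 log units; within the scatter), so these two groups, built from the same atoms, cannot be told apart here. The new group also keeps the gain seen with 3-ethylphenyl, with a 3.5-fold lower number from compound 2 to compound 4 (0.55 log units; beyond the scatter) and a 2.7-fold lower number from compound 1 to compound 4 (0.42 log units; beyond the scatter) on the same assay. The four compounds therefore form two sets, 3-ethylphenyl and 2,3-dimethylphenyl against 4-methylphenyl and 4-ethylphenyl, and none of the four goes against this split.

Nothing measured here explains why the sets differ. Also open, as far as these compounds go, is whether an amine or a carboxylic acid on the phenyl ring, or a longer chain in place of ethyl, would stay with the better set.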